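The source may report more compounds than this note shows. Statements on the series, on what has been measured and on what is new or still open speak of the compounds shown alone.

Compound 3 `O=C(O)Cc1sc(C(c2ccc(F)cc2)c2ccc(F)cc2)nc1-c1ccc(Cl)cc1` gives the highest number among the three measured compounds, 180 nM in an in vitro functional assay on HEK285-7 cells for antagonist activity at prostaglandin D2 receptor 2 (Homo sapiens), read by BRET and beta-arrestin recruitment; on this read-out higher numbers stand for weaker inhibition and lower numbers for stronger inhibition; compound 2 `O=C(O)Cc1sc(C(c2ccc(F)cc2)c2ccc(F)cc2)nc1-c1ccnc(Cl)c1` gives 39 nM and compound 1 `O=C(O)Cc1sc(C(c2ccc(F)cc2)c2ccc(F)cc2)nc1-c1ccnc(F)c1` gives 4.7 nM. The aromatic group on the shared core has carried weight in the measured steps: a 38-fold higher number from compound 1 to compound 3 (1.58 log units; beyond the scatter) and a 4.6-fold higher number from compound 2 to compound 3 (0.66 log units; beyond the scatter). Compound 4 `CS(=O)(=O)Nc1cccc(-c2nc(C(c3ccc(F)cc3)c3ccc(F)cc3)sc2CC(=O)O)c1` carries 3-(methanesulfonamido)phenyl in place of 4-chlorophenyl on an aromatic carbon. Within the data shown here, no measured step exchanges one phenyl-type group for another on that carbon, so the direction of the step is open. The earlier changes at that carbon were sizeable, and a shift beyond the scatter in either direction seems plausible. Compound 4 is expected to give about 50 nM in this assay, within 5 nM to 500 nM. This estimate corresponds to an expected 3.6-fold lower number from compound 3 to compound 4 (0.56 log units; beyond the scatter).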

Compound 4, half-maximal inhibitory concentration: 370 nM
The estimate for compound 4 lay 7.4-fold (0.87 log units) below the measured number; low and high end bracket the measured number.
By their numbers in this assay, from the lowest: compound 1; then compound 2; then compound 3; then compound 4.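

Exchanging one phenyl-type group for another on this carbon changed the number only modestly (a 2.1-fold higher number from compound 3 to compound 4 (0.31 log units; beyond the scatter)), and 3-(methanesulfonamido)phenyl, with its larger group, did not bring back the stronger inhibition seen with the pyridinyl groups. The gaps to those compounds remain wide (a 9.5-fold higher number from compound 2 to compound 4 (0.98 log units; beyond the scatter); a 79-fold higher number from compound 1 to compound 4 (1.90 log units; beyond the scatter)), the second being large. Nothing available explains these differences.

The compounds shown leave open whether a methanesulfonamido group on the pyridine ring would hold the number of compound 1. They also leave open how an amine or a carboxylic acid would fare in place of the ring fluoro group.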